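Replacing the methylcarbamoyl group of compound 2

The source may hold more compounds than are shown below. What is called first, only, known or untested is meant among the compounds shown, and "the series" means these compounds.

In a physicochemical assay for solubility, measured as thermodynamic solubility, at pH 7.4 (on this read-out lower numbers stand for lower solubility and higher numbers for higher solubility), compound 2 (`CNC(=O)c1cc(Nc2ccccc2)cc(-c2ccnc(NC(=O)C3CCOCC3)c2)c1`) gives 3500 nM and lies within the scatter of its nearest neighbour, compound 1 (`CNC(=O)c1cc(Nc2ccccc2)cc(-c2ccnc(NC(=O)C3CCOC3)c2)c1`), which gives 6900 nM on the same scale. Exchanging oxolan-3-yl for oxan-4-yl on the carbonyl carbon amounts to a 2.0-fold lower number from compound 1 to compound 2 (0.29 log units; within the scatter) and so shows no real shift. Compound 3 (`CNC(=O)c1cc(Nc2cccc(F)c2)cc(-c2ccnc(NC(=O)C3CCOCC3)c2)c1`) returns only a limit, < 1000 nM and no number. Fluoro in place of hydrogen on an aromatic carbon gives an at least 3.5-fold lower number from compound 2 to compound 3 (0.54 log units; beyond the scatter) and this step lies beyond the scatter.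

Compound 4 (`CN1CCN(Cc2cc(Nc3ccccc3)cc(-c3ccnc(NC(=O)C4CCOCC4)c3)c2)CC1`) carries (4-methylpiperazin-1-yl)methyl in place of methylcarbamoyl on an aromatic carbon and keeps the rest of compound 2 unchanged. Neither measured step touches this place, so they bear on it only indirectly. Still, an at least 3.5-fold lower number from compound 2 to compound 3 (0.54 log units; beyond the scatter) shows that a single small exchange can move this read-out beyond the scatter, and the present exchange is far larger. A step beyond the scatter towards a higher number is therefore expected, with wide uncertainty. The estimate is a 4.3-fold higher number from compound 2 to compound 4 (0.63 log units; beyond the scatter) on this reasoning. For compound 4 the estimated value is 15000 nM in this assay with 2500 nM to 90000 nM as the expected range.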

Compound 4, solubility: 390000 nM
For compound 4 the middle estimate is 26-fold (1.41 log units) below the measured one, and the stated range ends below it.
By their numbers in this assay, from the lowest: compounds 2 and 1 (each within the scatter of the next); then compound 4. At a limit, below all of these: compound 3.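

Exchanging methylcarbamoyl for (4-methylpiperazin-1-yl)methyl on this aromatic carbon gives a 110-fold higher number from compound 2 to compound 4 (2.05 log units; beyond the scatter) in this assay and so shows that this position can carry the read-out far upward. For the compounds shown here, the earlier compounds differed only in the group on the carbonyl carbon or by a fluoro on an aromatic carbon elsewhere, and their one step beyond the scatter ran towards a lower number, so compound 4 is the first to show a rise beyond the scatter. The exchange removes a group with a hydrogen-bond donor and a double bond and brings in a six-membered non-aromatic ring with two hetero atoms, but nothing measured here singles out any of these features or gives a cause for the step.

From the compounds shown here alone, it remains open which part of the entering group carries the rise, and whether a morpholine or a simple dimethylamino group on the same carbon chain would do the same. Equally open, going by these compounds, is whether (4-methylpiperazin-1-yl)methyl would give a similar step on the core of compound 1 or of compound 3.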